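The source may report more compounds than this note shows. Statements on the series, on what has been measured and on what is new or still open speak of the compounds shown alone.

Working notes. Two compounds of the series carry numbers in a functional assay on MCF7 cells (Homo sapiens) for inhibition, read by MTT assay, with a stated time of 48 h; a higher number here means a weaker inhibitor, a lower number a stronger inhibitor. Compound 1 `C=C1C(=O)N(c2ccccc2)N(C)C1c1ccccc1` gives 84400 nM in this assay. Compound 2 `C=C1CN(C)N(c2ccccc2)C1=O` gives 56000 nM in this assay; on the two numbers shown it stands beside compound 1 only, and a 1.5-fold lower number from compound 1 to compound 2 (0.18 log units; within the scatter). Compound 3 `C=C1C(=O)N(c2ccccc2)N(C)C1C` awaits measurement; it differs from compound 2 by methyl in place of hydrogen on a saturated ring carbon. Within the data shown here, the one step that bears on this change, at the same saturated ring carbon, was a 1.5-fold lower number from compound 1 to compound 2 (0.18 log units; within the scatter), so no move beyond the scatter is expected in this assay. The expected step is a 1.1-fold higher number from compound 2 to compound 3 (0.03 log units; within the scatter). For compound 3 the estimate is 60000 nM, within 25000 nM to 150000 nM.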

Compound 3, half-maximal inhibitory concentration: 153000 nM
Beside the measured number, compound 3's estimate is 2.6-fold (0.41 log units) below it; measured number above the stated range.
By their numbers in this assay, from the lowest: compounds 2, 1 and 3 (each within the scatter of the next, the first and the last beyond it).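

In this assay, among these compounds, the saturated ring carbon proves responsive to substitution: methyl in place of hydrogen gives the first step here that lies beyond the scatter (a 2.7-fold higher number from compound 2 to compound 3 (0.44 log units; beyond the scatter)). Methyl in place of phenyl stays within the scatter (a 1.8-fold higher number from compound 1 to compound 3 (0.26 log units; within the scatter)), so these two groups are not separated at this position. No supporting data explain the methyl step.

Going by these compounds, whether an ethyl group, a longer chain or an amine on this carbon would track compound 3 or compound 2 remains open. On these data alone, the effect of the same methyl change on other parts of the core also remains open.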